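The compounds below may be only part of what the source reports. "The series", "measured", "known", "first", "only" and "open" are said of these compounds alone.

Series notes. Compound 3 `CCNC(=O)c1cc(Oc2ccc(NC(=O)c3cc4cccnc4n(-c4ccccc4)c3=O)cc2)ccn1` is the N-ethyl amide analogue of compound 1 `CNC(=O)c1cc(Oc2ccc(NC(=O)c3cc4cccnc4n(-c4ccccc4)c3=O)cc2)ccn1`; compound 2 `CNC(=O)c1cc(Oc2ccc(NC(=O)c3cc4cccnc4n(-c4ccc(Br)cc4)c3=O)cc2)ccn1` carries a bromo group on the pendant phenyl of compound 1. In a functional assay on A549 cells (Homo sapiens) for antiproliferative activity, read by MTT assay, with a stated time of 72 h (on this read-out lower numbers stand for stronger inhibition and higher numbers for weaker inhibition), compound 1 gives 200 nM, compound 2 gives 1050 nM, and compound 3 gives 160 nM. Among the three, compound 3 shows the lowest number, but the gap to compound 1 is within the scatter, so no order between those two can be claimed; compound 2 sits well apart from both.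

Two steps are on record: a 1.3-fold lower number from compound 1 to compound 3 (0.10 log units; within the scatter), and a 5.3-fold higher number from compound 1 to compound 2 (0.72 log units; beyond the scatter). Compound 4 `CCNC(=O)c1cc(Oc2ccc(NC(=O)c3cc4cccnc4n(-c4ccc(OC)cc4)c3=O)cc2)ccn1` differs from compound 3 by methoxy in place of hydrogen on an aromatic carbon. Among the compounds with values here, the step from compound 1 to compound 2 is the only measured change at that same place, and it cost potency; the methoxy group is a different substituent, so the size of any loss is uncertain. In this assay a modest loss is therefore expected, a 2.5-fold higher number from compound 3 to compound 4 (0.40 log units; beyond the scatter). Compound 4 is estimated at 400 nM, with a range from 150 nM to 1100 nM.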

Compound 4, half-maximal inhibitory concentration: 2010 nM
For compound 4 the middle estimate is 5.0-fold (0.70 log units) below the measured one; measured number above the stated range.
By their numbers in this assay, from the lowest: compounds 3 and 1 (each within the scatter of the next); then compounds 2 and 4 (each within the scatter of the next).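

In this assay methoxy on the aromatic carbon para to a large group brings a large loss (a 13-fold higher number from compound 3 to compound 4 (1.10 log units; beyond the scatter)), so the loss seen with bromo (a 5.3-fold higher number from compound 1 to compound 2 (0.72 log units; beyond the scatter)) is not confined to that one substituent. Both substituents shown at this place raise the number, one on the N-methyl amide and one on the N-ethyl amide, although each appears on only one of the two amides. Nothing on hand gives a reason for this loss.

The compounds shown leave open whether fluoro or methyl at this place would keep the number near those of the unsubstituted phenyl compounds, and whether an amine would follow bromo and methoxy. Also open, going by these compounds, is whether a longer chain on the amide would change the picture.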